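The compounds below may be only part of what the source reports. "The series", "measured", "known", "first", "only" and "open" are said of these compounds alone.

Compound 2 `CC(C)(C)C(=O)N1CCC[C@H]1C(=O)N1CCC(NS(=O)(=O)c2cc(S(=O)(=O)c3ccccc3)ccc2C(F)(F)F)CC1` holds the lower of the two numbers measured in an assay on isolated protein for binding affinity to secreted frizzled-related protein 1 (Homo sapiens), read by fluorescence; a lower number here means a stronger inhibitor, a higher number a weaker inhibitor: compound 2 gives 40 nM, while compound 1 `O=C1CC[C@@H](C(=O)N2CCC(NS(=O)(=O)c3cc(S(=O)(=O)c4ccccc4)ccc3C(F)(F)F)CC2)N1` gives 90 nM. Among the compounds with values here, the only measured step, a 2.3-fold lower number from compound 1 to compound 2 (0.35 log units; beyond the scatter), came with 1-((tert-butyl)carbonyl)pyrrolidin-2-yl in place of 5-oxopyrrolidin-2-yl on a carbonyl carbon, a modest gain.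

Compound 3 `O=C([C@@H]1CCCN1C(=O)Nc1ccccc1)N1CCC(NS(=O)(=O)c2cc(S(=O)(=O)c3ccccc3)ccc2C(F)(F)F)CC1` differs from compound 2 by anilino in place of tert-butyl on a carbonyl carbon, on a carbonyl carbon whose other neighbour is the amide-type nitrogen in a ring; cut one bond further out, the change reads (tert-butyl)carbonyl to phenylcarbamoyl.

Within the data shown here, no measured step touches this group, so there is no direct guide. The step from compound 1 to compound 2 shows that this part of the molecule shifts the number only modestly. He therefore expects no step beyond the scatter for compound 3, a 1.3-fold higher number from compound 2 to compound 3 (0.10 log units; within the scatter). His estimate for compound 3 in this assay is 50 nM, within a range of 15 nM to 160 nM.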

Compound 3, half-maximal inhibitory concentration: 20 nM
Beside the measured number, compound 3's estimate is 2.5-fold (0.40 log units) above it; low and high end bracket the measured number.
By their numbers in this assay, from the lowest: compounds 3 and 2 (each within the scatter of the next); then compound 1.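

In this assay, the step of a 2.0-fold lower number from compound 2 to compound 3 (0.30 log units; within the scatter) shows that on this carbonyl carbon, whose other neighbour is the amide-type nitrogen in a ring, anilino can stand in place of tert-butyl with no change beyond the scatter. The earlier step altered the whole group on the carbonyl carbon of the core, whereas this one alters only the end of the acyl group, and it brings in a six-membered aromatic ring and a hydrogen-bond donor while the number stays within the scatter. Nothing available here explains why this exchange leaves the number within the scatter.

Still open, as far as these compounds go, is whether the ring or the amide hydrogen of anilino matters more, which a phenoxy or an N-methylanilino group on the same carbonyl carbon could separate. Also open, from the compounds shown here alone, is how a chlorine or a methoxy group on the phenyl ring of anilino would move the number.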